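From acetyl to a larger group at the limit

The source may report more compounds than this note shows. Statements on the series, on what has been measured and on what is new or still open speak of the compounds shown alone.

In an ADME assay on MDBK cells (Bos taurus) for cytotoxicity, read by MTT assay, with a stated time of 96 h (a higher number here means that more compound is tolerated, a lower number that less compound is tolerated), compound 1 `CC(=O)c1ccc2[nH]c(-c3ccc(Cl)cc3)nc2c1` gives > 100000 nM and this is a limit, not a number. Compound 2 `CC(=O)c1ccc2[nH]c(-c3ccc(C(F)(F)F)cc3)nc2c1` gives > 100000 nM and this too is a limit. Compound 3 `COc1ccc(-c2nc3cc(C(C)=O)ccc3[nH]2)c(OC)c1OC` gives > 100000 nM and this is again a limit. All three share the limit of > 100000 nM in this assay, at which 3 of the 3 values shown sit, as their reading, so compound 1 has no number to rank it by.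

Compound 4 `C/C(=N\O)c1ccc2[nH]c(-c3ccc(Cl)cc3)nc2c1` changes compound 1 at the acetyl: a group of 4 heavy atoms (2 carbon, 1 nitrogen, 1 oxygen; no ring) in place of a group of 3 heavy atoms (2 carbon, 1 oxygen; no ring), on an aromatic carbon on an aromatic carbon. Going by the values given here, the one measured step is a step that the two limits leave unreadable from compound 1 to compound 2 and it leaves the acetyl untouched, so it gives no size to carry over.

With all three compounds at the limit of > 100000 nM in this assay, at which 3 of the 3 values shown sit, no change beyond the scatter is expected, and the estimated step is a number no higher from compound 1 to compound 4 (the limit leaves the size open) in this assay here. Compound 4 is estimated at 100000 nM with an expected range from 40000 nM to 200000 nM in the same test.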

Compound 4, half-maximal cytotoxic concentration: 37000 nM
Compound 4: middle estimate off by 2.7-fold (0.43 log units), on the high side; the measured number lies below the stated range.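

Exchanging the acetyl for this larger group gives an at least 2.7-fold lower number from compound 1 to compound 4 (0.43 log units; beyond the scatter) in this assay. Going by these compounds alone, this is the first readable step, and it shows that a change at this position can bring the reading off the limit. The size remains only a lower bound because compound 1 has a limit and not a number: the limit of > 100000 nM in this assay, at which 3 of the 4 values shown sit.

Going by these compounds, whether the same exchange lowers the number in compound 2 or compound 3 stays open. So does what an amine or a carboxylic acid on this aromatic carbon would give.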